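Cytotoxicity limits in the series: expectation for compound 4

The source may hold more compounds than are shown below. What is called first, only, known or untested is meant among the compounds shown, and "the series" means these compounds.

Values in an ADME assay on Huh-7 cells (Homo sapiens) for cytotoxicity, read by XTT assay, with a stated time of 2 days; on this read-out higher numbers stand for lower toxicity in this test and lower numbers for higher toxicity in this test:
Compound 1 `O=C(O)[C@@H]1CC[C@H](n2ccc(=O)[nH]c2=O)O1`: > 250 ug/mL, a limit.
Compound 2 `COC(=O)[C@@H]1CC[C@H](n2ccc(N)nc2=O)O1`: > 250 ug/mL, a limit.
Compound 3 `[N-]=[N+]=N[C@H]1C[C@H](n2ccc(=O)[nH]c2=O)O[C@@H]1C(=O)O`: > 250 ug/mL, a limit.

Compound 3 thus has no number, only > 250 ug/mL as a limit. All three compounds stand at the limit of > 250 ug/mL in this assay, at which 3 of the 3 values shown sit.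

Compound 4 `Cc1cn([C@H]2C[C@H](N=[N+]=[N-])[C@@H](C(=O)O)O2)c(=O)[nH]c1=O` differs from compound 3 by methyl in place of hydrogen on an aromatic carbon.

Among the measured compounds shown here, the only measured step is a step that the two limits leave unreadable from compound 1 to compound 3, and it is azido in place of hydrogen on a saturated ring carbon. It gives no size to carry over. The expected change, a number no higher from compound 3 to compound 4 (the limit leaves the size open), is therefore none beyond the scatter in this assay. For compound 4 the estimate is 250 ug/mL, with an expected range of 120 ug/mL to 500 ug/mL.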

Compound 4, half-maximal cytotoxic concentration: > 250 ug/mL
Compound 4 was reported as a limit (the forecaster's own chance of this, stated with the estimate: 85%); the middle value sits exactly at the limit.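

In this assay, compound 3 and compound 4 are both reported only as limits, so no step can be read for methyl in place of hydrogen on an aromatic carbon: the limit of > 250 ug/mL in this assay, at which 4 of the 4 values shown sit. The compounds shown leave open what cytotoxic concentration any of them would reach, and whether either change shifts it.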